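Replacing hydroxy with chloro on an aromatic ring

The source may hold more compounds than are shown below. What is called first, only, known or untested is meant among the compounds shown, and "the series" means these compounds.

Among the measured compounds shown here, in a functional assay on NCI-H1299 cells (Homo sapiens) for inhibition, read by CCK-8 assay, with a stated time of 72 h, tested at 10 uM (on this read-out lower numbers stand for less inhibition of growth and higher numbers for more inhibition of growth at the one concentration tested), compound 3 (`CN(C)C(=O)c1cc2cnc(Nc3ccc(NC(=O)C4(C(=O)Nc5cccc(O)c5)CC4)cc3)nc2n1C1CCCC1`) gives 78.5%, the lowest of the three numbers so far. Compound 1 (`CN(C)C(=O)c1cc2cnc(Nc3ccc(NC(=O)C4(C(=O)Nc5ccc(F)cc5)CC4)cc3)nc2n1C1CCCC1`) gives 90.8%, and compound 2 (`CN(C)C(=O)c1cc2cnc(Nc3ccc(NC(=O)C4(C(=O)Nc5ccc(Cl)cc5)CC4)cc3)nc2n1C1CCCC1`) gives 88.6%.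

Compound 4 (`CN(C)C(=O)c1cc2cnc(Nc3ccc(NC(=O)C4(C(=O)Nc5cccc(Cl)c5)CC4)cc3)nc2n1C1CCCC1`) differs from compound 3 at a single site: chloro in place of hydroxy on an aromatic carbon. Chloro takes the place of hydroxy on an aromatic carbon, turning the 3-hydroxyphenyl into 3-chlorophenyl.

The closest measured comparison is a number 10.1 percentage points lower from compound 2 to compound 3 (beyond the scatter), which replaces 4-chlorophenyl with 3-hydroxyphenyl. The matching change from 4-fluorophenyl is a number 12.3 percentage points lower from compound 1 to compound 3 (beyond the scatter). Exchanging the two halogens gave only a number 2.2 percentage points lower from compound 1 to compound 2 (within the scatter). Neither hydroxy comparison keeps the substituent in the same place, so the data do not show how much the chloro's place matters. Reversing those two modest steps still suggests a rise of similar size. The expected change is a number 10.5 percentage points higher from compound 3 to compound 4 (beyond the scatter). Compound 4 is estimated at 89%, with an expected range of 80% to 95%.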

Compound 4, percent growth inhibition at one concentration: 84.1%
Compound 4: the middle estimate sits 4.9 percentage points above what was measured, and the stated range covers the measured number.
By their numbers in this assay, from the lowest: compounds 3, 4, 2 and 1 (each within the scatter of the next, the first and the last beyond it).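

In this assay, chloro in place of hydroxy gives a number 5.6 percentage points higher from compound 3 to compound 4 (within the scatter), so this swap on the ring, which removes a hydrogen-bond donor and a hydrogen-bond acceptor, has no effect that can be told from the scatter. The 3-chlorophenyl group also cannot be separated from the two earlier halogen-bearing groups, with a number 4.5 percentage points lower from compound 2 to compound 4 (within the scatter) and a number 6.7 percentage points lower from compound 1 to compound 4 (within the scatter), so the gaps that set compound 3 apart from compound 1 and compound 2 cannot be pinned on the swap of hydroxy for chloro alone, nor on the substituent's place alone. No measurement here offers an explanation for these numbers.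

Still open, from the compounds shown here alone, is how an amine or a carboxylic acid would read in place of chloro on this ring. Also open, going by these compounds, is whether hydroxy and chloro would differ at the ring place held by the 4-chlorophenyl group.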